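Methyl for Methylamino on a Thiophene Nucleoside Pair

The compounds below may be only part of what the source reports. "The series", "measured", "known", "first", "only" and "open" are said of these compounds alone.

Compound 1 `Cc1ncnc2c1c(-c1cccs1)cn2[C@@H]1O[C@H](CO)[C@@H](O)[C@H]1O`: > 20000 nM
Compound 2 `CNc1ncnc2c1c(-c1cccs1)cn2[C@@H]1O[C@H](CO)[C@@H](O)[C@H]1O`: > 20000 nM
Compound 3 `CNc1ncnc2c1c(-c1ccsc1)cn2[C@@H]1O[C@H](CO)[C@@H](O)[C@H]1O`: > 20000 nM

All three were tested in a functional assay on CCRF-CEM cells (Homo sapiens), read by MTT assay, with a stated time of 72 h; on this read-out higher numbers stand for weaker inhibition and lower numbers for stronger inhibition. In this assay compound 1 gives > 20000 nM, which is a limit of the assay rather than a number. Compound 2 likewise gives > 20000 nM, a limit. Compound 3 also gives > 20000 nM, again a limit.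

Between compound 2 and compound 1 the step is a step that the two limits leave unreadable from compound 2 to compound 1, made by methyl in place of methylamino on an aromatic carbon. Between compound 2 and compound 3 the step is a step that the two limits leave unreadable from compound 2 to compound 3, and the two cores differ by thiophen-3-yl in place of thiophen-2-yl on an aromatic carbon.

Compound 4 `Cc1ncnc2c1c(-c1ccsc1)cn2[C@@H]1O[C@H](CO)[C@@H](O)[C@H]1O` has not been measured. It differs from compound 3 by methyl in place of methylamino on an aromatic carbon. This is the same change that takes compound 2 to compound 1, the place being described in the same words for both.

Compound 4 is expected to sit at 30000 nM, with a range from 15000 nM to 100000 nM. The expected step that the limit leaves unreadable from compound 3 to compound 4 rests on (the limit of > 20000 nM in this assay, at which 3 of the 3 values shown sit), where every measured compound sits, so a further limit is the most likely outcome for compound 4.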

Compound 4, half-maximal inhibitory concentration: 11200 nM
The estimate for compound 4 lay 2.7-fold (0.43 log units) above the measured number, and the stated range ends above it.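

In this assay, methyl in place of methylamino gives an at least 1.7-fold lower number from compound 3 to compound 4 (0.25 log units; that floor lies within the scatter), while thiophen-3-yl in place of thiophen-2-yl gives an at least 1.7-fold lower number from compound 1 to compound 4 (0.25 log units; that floor lies within the scatter). Compound 4 is the only one of the four with a measured number, which makes each step a floor: the real gap could be larger, but neither floor alone shows a change beyond the scatter. The result therefore does not show that the methyl change carries from one core to another, since its step from compound 2 to compound 1 cannot be read, like every other step between two limits, because both ends of those steps are limits: the limit of > 20000 nM in this assay, at which 3 of the 4 values shown sit.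

The compounds shown leave open what a plain amino group or a longer chain such as ethyl would give in place of methyl on the core of compound 4. They also leave open whether either group would give a measured number on the core of compound 1.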